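Three close analogues at the floor of an adenosine binding assay

The compounds below may be only part of what the source reports. "The series", "measured", "known", "first", "only" and "open" are said of these compounds alone.

Compound 1 `Cc1c(Br)sc(N)c1C(=O)c1ccc(Cl)cc1` in a binding assay on CHO cells for displacement of a labelled ligand from adenosine receptor A1 (Homo sapiens), read by scintillation counting, tested at 10 uM (a lower number here means less inhibition, a higher number more inhibition at the concentration tested (going by the name of the read-out)), gives 1%.
Compound 2 `CC(C)(C)Cc1csc(N)c1C(=O)c1cccc(Cl)c1` in this assay gives 2%.
Compound 3 `CC(C)(C)Cc1c(-c2ccccn2)sc(N)c1C(=O)c1ccc(Cl)cc1` in this assay gives 1%.

All three measured compounds share a core built on a five-membered aromatic ring with one sulfur, carrying an amino group and a ketone to a chlorophenyl ring. Compound 3 stands level with compound 1 at the digits reported, and the two of them are the lowest of the three numbers; compound 2 lies only a single percentage point higher, so none of the three is separated from another beyond the usual scatter. In short, nothing in this set shows meaningful displacement of the labelled ligand.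

Compound 4 `CC(C)(C)Cc1c(-c2cc(F)ccc2F)sc(N)c1C(=O)c1ccc(Cl)cc1` is the next member. It differs from compound 3 in one place: 2,5-difluorophenyl in place of pyridin-2-yl on an aromatic carbon. The group that leaves carries one hydrogen-bond acceptor, the group that enters carries none, and the rest of the molecule is unchanged. Among the measured compounds shown here, since no measured pair in this set moves beyond the scatter, there is no basis for expecting compound 4 to behave differently; the step from compound 3 to compound 4 in this assay is expected to be a number 2 percentage points higher from compound 3 to compound 4 (within the scatter), that is, within the scatter. Compound 4 is therefore estimated at 3%, with a range from -5% to 12%.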

Compound 4, a percentage reported as inhibition, at one concentration (the size of the read-out at that concentration, not a potency): 3%
Compound 4: the middle estimate sits on the measured number at the digits printed; the measured number falls inside the stated range.
By their numbers in this assay, from the lowest: compounds 1, 3, 2 and 4 (each within the scatter of the next).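

In this assay, among the compounds shown here, putting 2,5-difluorophenyl in place of pyridin-2-yl on the aromatic carbon next to the ring sulfur gives a number 2 percentage points higher from compound 3 to compound 4 (within the scatter), and this is the first step in the set between compounds that differ in one place. So at this position, a six-membered aromatic ring of carbon only with two fluorines and a six-membered aromatic ring with a ring nitrogen and one hydrogen-bond acceptor cannot be told apart by this read-out, and the exchange leaves both compounds at the floor of the assay. Nothing shown here bears on why the read-out stays at this level.

For the compounds shown here, still open is whether any group at this position can separate itself from the floor, for instance a carboxylic acid, a morpholine or a simple primary amine on a short chain, since only two aromatic rings have been compared here. The same holds for the neighbouring position, where a cyclohexyl group or a shorter ethyl chain in place of neopentyl would show whether that site has any bearing on displacement of the labelled ligand.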